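The source may hold more compounds than are shown below. What is called first, only, known or untested is meant among the compounds shown, and "the series" means these compounds.

Compound 2 `Cc1ccc2[nH]c(=O)c(CN(Cc3ccc(OCCO)cc3)Cc3ccc(C(C)(C)C)cc3)cc2c1` was tested in a toxicity assay on MDCK cells (Canis lupus familiaris) for cytotoxicity, read by crystal violet staining, with a stated time of 48 h; on this read-out higher numbers stand for lower toxicity in this test and lower numbers for higher toxicity in this test. There compound 2 gives > 5000 nM, which is a limit of the assay and not a number. Compound 1 `Cc1ccc2cc(CN(Cc3ccc(F)cc3)Cc3ccc(C(C)C)cc3)c(=O)[nH]c2c1` likewise gives only a limit, > 33000 nM, in this assay. Among the compounds with values here, compound 2 thus stands at a limit, and the one further value shown is a limit as well. Compound 3 `Cc1ccc2[nH]c(=O)c(CN(Cc3ccc(C(C)(C)C)cc3)C(C)c3ccc(OC(F)F)cc3)cc2c1` is not yet measured; it differs from compound 2 by 1-(4-(difluoromethoxy)phenyl)ethyl in place of 4-(2-hydroxyethoxy)benzyl on an amine nitrogen. Within the data shown here, with no measured step to rest on, the expected step in this assay is estimated as a step that the limit leaves unreadable from compound 2 to compound 3, nothing beyond the scatter. Compound 3 is expected to give about 15000 nM, estimated between 4000 nM and 60000 nM.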

Compound 3, half-maximal cytotoxic concentration: > 5000 nM
Compound 3 ended at the assay's limit; the forecaster's own chance of this, stated with the estimate: 60%; the middle value is on the limit's open side.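

Within the data shown here, compound 2 and compound 3 both sit at a limit of the read-out in this assay, so no step between them can be read. The compounds shown leave open at what concentration any of them turns toxic to these cells.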